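Bromophenyl Carbamoylamino Replacing Fluorophenyl in the Quinoline Series

The source may hold more compounds than are shown below. What is called first, only, known or untested is meant among the compounds shown, and "the series" means these compounds.

Of the compounds shown here, three sharing one core have been measured in a functional assay on L1210 cells (Mus musculus) for inhibition, read by MTT assay, with a stated time of 72 h; a higher number here means a weaker inhibitor, a lower number a stronger inhibitor. Compound 1 `COc1cc(NC(C)CCCNC(=O)NNC(=O)Nc2cccc(F)c2)c2ncccc2c1` gives 108000 nM, compound 2 `COc1cc(NC(C)CCCNC(=O)NNC(=O)Nc2cc(C(F)(F)F)cc(C(F)(F)F)c2)c2ncccc2c1` gives 18000 nM, and compound 3 `COc1cc(NC(C)CCCNC(=O)Nc2ccc(F)cc2)c2ncccc2c1` gives 18000 nM. Compound 3 thus stands level with compound 2 at the digits printed, the two together holding the lowest numbers of the three, while compound 1 lies a clear distance higher: a 6.0-fold lower number from compound 1 to compound 3 (0.78 log units; beyond the scatter).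

Compound 4 `COc1cc(NC(C)CCCNC(=O)NNC(=O)Nc2ccc(Br)cc2)c2ncccc2c1` has not yet been measured in this assay. It differs from compound 3 in one place: ((4-bromophenyl)carbamoyl)amino in place of 4-fluorophenyl on an amide-type nitrogen. For the measured compounds named here, the only measured step that bears on this change is the one from compound 1 to compound 3, where the carbamoylamino linkage was removed and the number fell, a 6.0-fold lower number from compound 1 to compound 3 (0.78 log units; beyond the scatter); compound 4 puts such a linkage back, now carrying a 4-bromophenyl. Compound 2, however, carries the same linkage yet matches compound 3, so the reversal need not be full. A moderate rise in the number is therefore expected for compound 4, a 2.2-fold higher number from compound 3 to compound 4 (0.35 log units; beyond the scatter), giving an estimated 40000 nM with a range from 12000 nM to 130000 nM.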

Compound 4, half-maximal inhibitory concentration: 51000 nM
Beside the measured number, compound 4's estimate is 1.3-fold (0.11 log units) below it, and the stated range covers the measured number.
By their numbers in this assay, from the lowest: compounds 2 and 3 (each within the scatter of the next); then compound 4; then compound 1.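

For the compounds shown here, putting ((4-bromophenyl)carbamoyl)amino on the amide-type nitrogen in place of 4-fluorophenyl gives a 2.8-fold higher number from compound 3 to compound 4 (0.45 log units; beyond the scatter) in this assay, so a higher number with this linkage is no longer seen only in compound 1. On the linkage itself, 4-bromophenyl in place of 3-fluorophenyl gives a 2.1-fold lower number from compound 1 to compound 4 (0.33 log units; beyond the scatter) in the same assay, which shows that the aryl group carried by the linkage also moves the number. Nothing at hand explains either step.

Since this last step changes both the halogen and the name-position of the group, the compounds shown do not separate the two, and a 3-bromophenyl or a 4-fluorophenyl on the same linkage would be needed for that. From the compounds shown here alone, how a 4-chlorophenyl or a 4-methoxyphenyl on the linkage would read also remains open.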